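The source may report more compounds than this note shows. Statements on the series, on what has been measured and on what is new or still open speak of the compounds shown alone.

Measured compounds:
compound 1, `OC1CCCN(c2nc(-c3ccccn3)nc3c2CN(Cc2ccccc2)CC3)C1`, in an assay on FRT cells with Cystic fibrosis transmembrane conductance regulator variant F508del (Homo sapiens) as the target, read by fluorescence, with a stated time of 25 min (on this read-out lower numbers stand for an effect already at smaller amounts and higher numbers for an effect only at larger amounts of compound), compound 1 gives 2800 nM
compound 2, `CN(C)CCN1CCN(c2nc(-c3ccccn3)nc3c2CN(Cc2ccccc2)CC3)CC1`, compound 2 gives 1500 nM
compound 3, `CN(C)CCN1CCN(c2nc(-c3ccccn3)nc3c2CN(Cc2ccsc2)CC3)CC1`, compound 3 gives 200 nM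

Compound 3 gives the lowest number of the three; the step of a 7.5-fold lower number from compound 2 to compound 3 (0.88 log units; beyond the scatter) is beyond the scatter, and the gap between compound 1 and compound 3 is wider still, as their two values show. Compound 4, `CC(C)c1ccc(CN2CCc3nc(-c4ccccn4)nc(N4CCN(CCN(C)C)CC4)c3C2)cc1`, differs from compound 3 in one place: 4-isopropylphenyl in place of thiophen-3-yl on a saturated chain carbon bound to an amine nitrogen in a ring. Among the measured compounds shown here, only one measured step bears on this place, a 7.5-fold lower number from compound 2 to compound 3 (0.88 log units; beyond the scatter), where a six-membered ring of carbon only was exchanged for thiophen-3-yl and the number fell. The step of a 1.9-fold lower number from compound 1 to compound 2 (0.27 log units; within the scatter) sits elsewhere and is within the scatter, so it carries no weight here. Compound 4 goes back to a six-membered ring of carbon only, now bearing an isopropyl group for which no measurement exists in this series. A return toward the number of compound 2 is therefore expected, tempered by the unknown contribution of the isopropyl group. For compound 4 in this assay the expected step is a 3.5-fold higher number from compound 3 to compound 4 (0.54 log units; beyond the scatter). The estimate for compound 4 is 700 nM, with a range from 150 nM to 3000 nM.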

Compound 4, half-maximal effective concentration in the Cystic fibrosis transmembrane conductance regulator assay: 300 nM
Beside the measured number, compound 4's estimate is 2.3-fold (0.37 log units) above it; low and high end bracket the measured number.
By their numbers in the Cystic fibrosis transmembrane conductance regulator assay, from the lowest: compounds 3 and 4 (each within the scatter of the next); then compounds 2 and 1 (each within the scatter of the next).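

In the Cystic fibrosis transmembrane conductance regulator assay compound 2 gives 1500 nM and compound 4 gives 300 nM, and isopropyl in place of hydrogen on an aromatic carbon gives a 5.0-fold lower number from compound 2 to compound 4 (0.70 log units; beyond the scatter) and so this place responds to a group carried on the six-membered carbon ring, not only to the exchange of that ring for thiophen-3-yl. In the same assay the Cystic fibrosis transmembrane conductance regulator assay the exchange of thiophen-3-yl (5 heavy atoms) for 4-isopropylphenyl (9 heavy atoms) gives a 1.5-fold higher number from compound 3 to compound 4 (0.18 log units; within the scatter) and in a physicochemical assay for solubility, read by HPLC, with a stated time of 24 h, at pH 7.4, tested at 250 uM (a lower number here means a less soluble compound, a higher number a more soluble compound), it gives a 1.3-fold lower number from compound 3 to compound 4 (0.10 log units; within the scatter) so neither read-out separates the two groups, both steps being within the scatter. In the physicochemical assay compound 3 gives 235000 nM and compound 4 gives 186000 nM. No measurement at hand speaks to the reason for these steps.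

Open, on these data alone, is whether methyl, an amine or a carboxylic acid in place of the isopropyl group would keep the number of compound 4. Also open, as far as these compounds go, is whether the isopropyl step carries over to the 3-hydroxypiperidin-1-yl side of compound 1.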